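This account rests on a few compounds, and the source may have more. Where it says the series, first, only, none or still open, it means among the compounds named here.

Compound 1 `O=C1O[C@@H](CO)CN1c1ccc(-n2cc(-c3ccccn3)cn2)c(F)c1` carries a hydroxy group on a saturated chain carbon bound to a saturated ring carbon of the shared core. In an ADME assay on L02 cells (Homo sapiens) for cytotoxicity, read by MTT assay, with a stated time of 48 h (on this read-out lower numbers stand for stronger inhibition and higher numbers for weaker inhibition), compound 1 gives 59 ug/mL, the lowest of the two numbers measured in this assay. Compound 2 `CCC(=O)NC[C@H]1CN(c2ccc(-n3cc(-c4ccccn4)cn3)c(F)c2)C(=O)O1` gives 204 ug/mL in this assay. Compound 3 `O=CNC[C@H]1CN(c2ccc(-n3cc(-c4ccccn4)cn3)c(F)c2)C(=O)O1` reaches only a limit of this assay, > 400 ug/mL, so no number is known for it (the limit of > 400 ug/mL in this assay, at which 1 of the 3 values shown sits). Compound 4 `CN(C)S(=O)(=O)NC[C@H]1CN(c2ccc(-n3cc(-c4ccccn4)cn3)c(F)c2)C(=O)O1` has not yet been measured in this assay; it differs from compound 1 in one place: (dimethylsulfamoyl)amino in place of hydroxy on a saturated chain carbon bound to a saturated ring carbon. For the measured compounds named here, two measured steps bear on this change, since each swaps the same hydroxy group at the same place for a larger group: a 3.5-fold higher number from compound 1 to compound 2 (0.54 log units; beyond the scatter) and an at least 6.7-fold higher number from compound 1 to compound 3 (0.83 log units; beyond the scatter). Both steps gave weaker cytotoxicity beyond the scatter, so for compound 4 a higher number than for compound 1 is expected as well, roughly a 3.7-fold higher number from compound 1 to compound 4 (0.57 log units; beyond the scatter). Compound 4 is therefore estimated at 220 ug/mL in this assay, with a range from 90 ug/mL to 400 ug/mL.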

Compound 4, half-maximal inhibitory concentration: 158 ug/mL
Beside the measured number, compound 4's estimate is 1.4-fold (0.14 log units) above it; the range from low to high includes it.
By their numbers in this assay, from the lowest: compound 1; then compounds 4 and 2 (each within the scatter of the next). At a limit, above all of these: compound 3.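

In this assay, (dimethylsulfamoyl)amino in place of hydroxy gives a 2.7-fold higher number from compound 1 to compound 4 (0.43 log units; beyond the scatter), so on this saturated chain carbon bound to a saturated ring carbon, the rise seen with propanoylamino and formylamino also appears with a sulfur-containing group. On the amine nitrogen, dimethylsulfamoyl in place of propanoyl gives a 1.3-fold lower number from compound 2 to compound 4 (0.11 log units; within the scatter), so those two groups cannot be told apart here, whereas dimethylsulfamoyl in place of formyl gives an at least 2.5-fold lower number from compound 3 to compound 4 (0.40 log units; beyond the scatter). Compound 3 gives only a limit, not a number: the limit of > 400 ug/mL in this assay, at which 1 of the 4 values shown sits.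

The compounds shown leave open how a free amine or a carboxylic acid in place of hydroxy would read in this assay. Also open, as far as these compounds go, is whether a longer chain on the carbonyl, such as butanoyl, would read like propanoyl or differently.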